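The compounds below may be only part of what the source reports. "The series", "measured", "known", "first", "only" and "open" are said of these compounds alone.

Measured so far in a functional assay on NCI-H460 cells (Homo sapiens) for inhibition, read by sulforhodamine B assay, with a stated time of 72 h; a lower number here means a stronger inhibitor, a higher number a weaker inhibitor:

compound 1, `O=c1[nH]c2ccc(Br)cc2nc1/C=C/c1ccc(Br)cc1`, 0.0363 ug/mL
compound 2, `O=c1[nH]c2ccc(Br)cc2nc1/C=C/c1ccc(O)cc1`, 0.0228 ug/mL
compound 3, `Cc1ccc(/C=C/c2nc3cc(Br)ccc3[nH]c2=O)cc1`, 0.00812 ug/mL

Compound 3 gives the lowest number of the three in this assay. Its steps to the others are both beyond the scatter: a 4.5-fold lower number from compound 1 to compound 3 (0.65 log units; beyond the scatter) and a 2.8-fold lower number from compound 2 to compound 3 (0.45 log units; beyond the scatter). The step of a 1.6-fold lower number from compound 1 to compound 2 (0.20 log units; within the scatter) is within the scatter.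

Compound 4, `COc1ccc(/C=C/c2nc3cc(Br)ccc3[nH]c2=O)cc1`, differs from compound 3 by methoxy in place of methyl on an aromatic carbon. For the measured compounds named here, no measured step changes methyl into methoxy. Going by the values given here, the steps that bear on it are those ending at compound 3, which show a modest lowering when methyl replaces bromo or hydroxy, and the step from compound 1 to compound 2, which shows hydroxy and bromo giving numbers within the scatter of each other. Methoxy shares an acceptor with hydroxy and a carbon with methyl, so the expected outcome lies between the numbers of compound 2 and compound 3, with the change from compound 3 to compound 4 expected to stay within the scatter: a 1.5-fold higher number from compound 3 to compound 4 (0.17 log units; within the scatter). Compound 4 is therefore expected at 0.012 ug/mL in this assay, estimated between 0.005 ug/mL and 0.03 ug/mL.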

Compound 4, half-maximal inhibitory concentration: 0.00006 ug/mL
Compound 4: the middle estimate sits 200-fold (2.30 log units) above what was measured; the whole stated range lies above it.
By their numbers in this assay, from the lowest: compound 4; then compound 3; then compounds 2 and 1 (each within the scatter of the next).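

At this position, on an aromatic carbon para to a large group, bromo, hydroxy and methyl gave steps that were within the scatter or modest, whereas methoxy gives far larger ones in this assay: a 140-fold lower number from compound 3 to compound 4 (2.13 log units; beyond the scatter), a 380-fold lower number from compound 2 to compound 4 (2.58 log units; beyond the scatter) and a 610-fold lower number from compound 1 to compound 4 (2.78 log units; beyond the scatter). Neither the oxygen nor the methyl alone reproduces this, as compound 2 carries the oxygen and compound 3 the methyl, and only their combination as methoxy in compound 4 gives a step of this size. No supporting data bear on why this single change has so large an effect.

The compounds shown leave open whether the effect is specific to methoxy or extends to ethoxy, a longer chain on the same oxygen, or an amine at this position. They also leave open whether it holds when another group replaces the bromo on the shared core.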